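Amino removal on the aromatic carbon in two cores

The source may report more compounds than this note shows. Statements on the series, on what has been measured and on what is new or still open speak of the compounds shown alone.

Measured so far in a functional assay on MT4 cells (Homo sapiens) for inhibition; a lower number here means a stronger inhibitor, a higher number a weaker inhibitor:
compound 1 `C=C1[C@@H](O)[C@H](n2cnc3c(N)nc(N)nc32)O[C@@H]1CO` gives > 200000 nM, a limit of the assay.
compound 2 `C=C1[C@@H](O)[C@H](n2cnc3c(N)ncnc32)O[C@@H]1CO` gives 43000 nM.
compound 3 `C=C1[C@H](n2cnc3c(N)nc(N)nc32)O[C@H](CO)[C@H]1O` gives > 500000 nM, a limit of the assay.

Compound 2 differs from compound 1 by hydrogen in place of amino on an aromatic carbon. This change gave an at least 4.6-fold lower number from compound 1 to compound 2 (0.66 log units; beyond the scatter), and since compound 1 sits at the limit (the limit of > 200000 nM in this assay, at which 1 of the 3 values shown sits), only the lower bound of that step is known.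

Compound 4 `C=C1[C@H](n2cnc3c(N)ncnc32)O[C@H](CO)[C@H]1O` stands to compound 3 as compound 2 stands to compound 1: it carries hydrogen in place of amino on an aromatic carbon, the same change at the same place. The difference between the core of compound 1 and the core of compound 3 is not broken down here. Compound 3 sits at the limit (the limit of > 500000 nM in this assay, at which 1 of the 3 values shown sits), so any step from it can only be read as a bound.

The same direction is expected for compound 4, about an at least 3.3-fold lower number from compound 3 to compound 4 (0.52 log units; beyond the scatter), resting on an at least 4.6-fold lower number from compound 1 to compound 2 (0.66 log units; beyond the scatter) alone. For compound 4 the expected value in this assay is 150000 nM, between 40000 nM and 500000 nM, with a fair chance that only a limit is reported.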

Compound 4, half-maximal inhibitory concentration: 131000 nM
For compound 4 the middle estimate is 1.1-fold (0.06 log units) above the measured one, within the range that was stated.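

In this assay, hydrogen in place of amino on an aromatic carbon gave an at least 3.8-fold lower number from compound 3 to compound 4 (0.58 log units; beyond the scatter), so the direction seen on the core of compound 1 also holds on the second core. Compound 3 gives > 500000 nM, which is a limit of the assay, and the step from it can be read only as a bound. The direction of the change therefore carries from one core to the other, but its size is not shown to carry over: the same change on two cores in this assay, an at least 4.6-fold lower number (0.66 log units; beyond the scatter) from compound 1 to compound 2 and an at least 3.8-fold lower number (0.58 log units; beyond the scatter) from compound 3 to compound 4; the limit leaves it open whether they differ

The compounds shown hold only amino or hydrogen on the aromatic carbon between two ring nitrogen atoms, so it remains open how a methyl group, a chlorine atom or a hydroxyl group would read there in this assay. From the compounds shown here alone, it also remains open whether the same direction would hold on any core beyond these two.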